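The source may report more compounds than this note shows. Statements on the series, on what has been measured and on what is new or still open speak of the compounds shown alone.

Compound 1 `Fc1cccnc1N1CCN(Cc2nc3ccccc3[nH]2)CC1` gives 27% in an assay on HEK293 cells with D(4) dopamine receptor (Homo sapiens) as the target, read by FLIPR; a higher number here means a larger maximal response, a lower number a smaller maximal response. Compound 2 `N#Cc1cccnc1N1CCN(Cc2nc3ccccc3[nH]2)CC1` gives 50% in this assay. Compound 3 `CCOc1ccccc1N1CCN(Cc2nc3ccccc3[nH]2)CC1` gives 31% in this assay.

Compound 1 stands lowest of the three numbers; compound 3 sits within the scatter of it, and compound 2 sits higher by a number 23 percentage points higher from compound 1 to compound 2 (beyond the scatter). Compound 4 `Cc1cccc(N2CCN(Cc3nc4ccccc4[nH]3)CC2)n1` differs from compound 1 as follows: 6-methylpyridin-2-yl in place of 3-fluoropyridin-2-yl on an amine nitrogen in a ring. Going by the values given here, the single measured step, a number 23 percentage points higher from compound 1 to compound 2 (beyond the scatter), swaps a group on the aromatic ring, not the whole ring on the amine nitrogen, so no measured step closely matches this change. With so little to go on, no step beyond the scatter is expected. Compound 4 is therefore estimated at 30%, between 15% and 50%. The expected step would be a number 3 percentage points higher from compound 1 to compound 4 (within the scatter), inside the scatter.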

Compound 4, largest response reached (reported as efficacy), in percent of the reference or control that the assay uses: 36%
Beside the measured number, compound 4's estimate is 6 percentage points below it; low and high end bracket the measured number.
By their numbers in this assay, from the lowest: compounds 1, 3 and 4 (each within the scatter of the next); then compound 2.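

Putting 6-methylpyridin-2-yl in place of 3-fluoropyridin-2-yl on the amine nitrogen gives a number 9 percentage points higher from compound 1 to compound 4 (within the scatter), so this swap of the whole substituted ring does not separate compound 4 from compound 1. The same place does separate compound 4 from the nitrile-bearing ring, with a number 14 percentage points lower from compound 2 to compound 4 (beyond the scatter), so among these three pyridines only compound 2 stands apart. Nothing measured here explains that difference. On these data alone, it remains open whether an amine or a carboxylic acid on this pyridine ring would match compound 2 or stay with compound 1 and compound 4.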